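Oxime Ethers on Piperazine: From Nitrile Phenyl to Pyrimidine

This account rests on a few compounds, and the source may have more. Where it says the series, first, only, none or still open, it means among the compounds named here.

Three compounds set the scene. Compound 1 `O/N=C(/CCN1CCN(c2ccccn2)CC1)c1cc(F)cc(F)c1` and compound 2 `O/N=C(\CCN1CCN(c2ccccn2)CC1)c1ccc(F)cc1F` carry a pyridin-2-yl group on the piperazine, while compound 3 `CCO/N=C(\CCN1CCN(c2ccccc2C#N)CC1)c1ccccc1` carries a 2-cyanophenyl group and an ethyl oxime ether. In a functional assay on HEK293 cells with D(4) dopamine receptor (Homo sapiens) as the target, read by FLIPR (on this read-out higher numbers stand for larger maximal responses and lower numbers for smaller maximal responses), compound 1 gives 70%, compound 2 gives 78%, and compound 3 gives 82%. Compound 3 thus shows the highest of the three numbers, but compound 2 lies within the usual scatter of it, and only compound 1 falls beyond that scatter.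

Compound 4 `CCO/N=C(\CCN1CCN(c2ncccn2)CC1)c1ccccc1` differs from compound 3 in one place: pyrimidin-2-yl in place of 2-cyanophenyl on an amine nitrogen in a ring. Among the compounds with values here, no measured pair covers this change, so the direction is open. Compound 1 gives 70% and compound 2 gives 78%, and both carry a six-membered aromatic ring with nitrogen on the ring amine. On that basis the author expects for compound 4 a small step, if any, downward, namely a number 10 percentage points lower from compound 3 to compound 4 (within the scatter). Compound 4 is therefore estimated to give 72% in this assay, within a range from 55% to 88%.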

Compound 4, largest response reached (reported as efficacy), in percent of the reference or control that the assay uses: 26%
Estimate against measurement, compound 4: 46 percentage points above, and the stated range ends above it.
By their numbers in this assay, from the lowest: compound 4; then compounds 1, 2 and 3 (each within the scatter of the next, the first and the last beyond it).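

In this assay, within the data shown here, with the ethyl oxime ether and the rest of the core held fixed, putting pyrimidin-2-yl in place of 2-cyanophenyl on the amine nitrogen in the ring gives a number 56 percentage points lower from compound 3 to compound 4 (beyond the scatter) as the only single-place step in the set. It shows that the maximal response is highly sensitive to which aromatic group sits on this nitrogen, and that two six-membered aromatic rings on the same atom need not behave alike. Nothing measured here gives a reason for the size of this step.

The compounds shown leave open whether the loss tracks the departing nitrile or the entering ring nitrogens, which a plain phenyl or a 2-methoxyphenyl group on the same core could separate. They also leave open whether the step holds when a methyl or a longer alkyl chain replaces the ethyl group on the oxime oxygen.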